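Chain extension at the sulfur in the uracil-free dinucleotide series

The compounds below may be only part of what the source reports. "The series", "measured", "known", "first", "only" and "open" are said of these compounds alone.

Three congeners of one core have numbers in an in vitro functional assay on 1321-N1 cells for agonist activity at P2Y purinoceptor 6 (Homo sapiens); on this read-out higher numbers stand for an effect only at larger amounts of compound and lower numbers for an effect already at smaller amounts. Compound 1 `O=C(O)CSc1ccn([C@@H]2O[C@H](COP(=O)(O)OP(=O)(O)O)[C@@H](O)[C@H]2O)c(=O)n1` gives 1700 nM; compound 2 `O=c1nc(SCc2ccccc2)ccn1[C@@H]1O[C@H](COP(=O)(O)OP(=O)(O)O)[C@@H](O)[C@H]1O` gives 800 nM; compound 3 `CSc1ccn([C@@H]2O[C@H](COP(=O)(O)OP(=O)(O)O)[C@@H](O)[C@H]2O)c(=O)n1` gives 2300 nM. On these numbers compound 3 stands highest, though its gap to compound 1 is within the scatter and only its gap to compound 2 is beyond it: a 2.9-fold higher number from compound 2 to compound 3 (0.46 log units; beyond the scatter), while a 1.4-fold higher number from compound 1 to compound 3 (0.13 log units; within the scatter), and a 2.1-fold lower number from compound 1 to compound 2 (0.33 log units; beyond the scatter).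

Compound 4 `O=C(O)CCCSc1ccn([C@@H]2O[C@H](COP(=O)(O)OP(=O)(O)O)[C@@H](O)[C@H]2O)c(=O)n1` is not yet measured. Relative to compound 3 the change is 2-carboxyethyl in place of hydrogen on a saturated chain carbon bound to a sulfur. Among the measured compounds shown here, two measured steps bear on it, both read in reverse: adding carboxy in place of hydrogen on that carbon (a 1.4-fold higher number from compound 1 to compound 3 (0.13 log units; within the scatter)) moved nothing beyond the scatter, whereas adding phenyl in place of hydrogen (a 2.9-fold higher number from compound 2 to compound 3 (0.46 log units; beyond the scatter)) gave a modestly lower number. For the measured compounds named here, the 2-carboxyethyl group is larger than carboxy and carries the same donor and acceptor; no measured pair shows the effect of lengthening the chain. A step toward a lower number, small and possibly within the scatter, is therefore expected: a 1.5-fold lower number from compound 3 to compound 4 (0.19 log units; within the scatter). For compound 4 in this assay the estimate is 1500 nM, with a range from 600 nM to 3500 nM.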

Compound 4, half-maximal effective concentration: 8800 nM
Compound 4: the middle estimate sits 5.9-fold (0.77 log units) below what was measured; the whole stated range lies below it.
By their numbers in this assay, from the lowest: compound 2; then compounds 1 and 3 (each within the scatter of the next); then compound 4.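

In this assay, among the compounds shown here, the step from hydrogen to 2-carboxyethyl on a saturated chain carbon bound to a sulfur gives a 3.8-fold higher number from compound 3 to compound 4 (0.58 log units; beyond the scatter) and is the first change from compound 3 to raise the number beyond the scatter. A carboxy end alone does not account for this, since compound 1, with carboxy on the same carbon, stays within the scatter of compound 3, whereas replacing that carboxy with 2-carboxyethyl gives a 5.2-fold higher number from compound 1 to compound 4 (0.71 log units; beyond the scatter) and so shows that the longer acid-bearing chain reads differently from the short one. For the compounds shown here, the group on this carbon can also move the number in both directions from compound 3, with phenyl lowering it and 2-carboxyethyl raising it, and the direct exchange of these two groups gives an 11-fold higher number from compound 2 to compound 4 (1.04 log units; beyond the scatter) as the only large step.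

Open, as far as these compounds go, is whether the rise tracks chain length or the acid end, which a plain butyl chain, a methyl ester or an amine at the same chain end would separate, and whether a longer carboxylic acid chain would raise the number further. Nothing at hand gives a reason for any of these steps.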